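Halogenated aryl swap on the anilino nitrogen: compound 4

A few compounds are considered here, and "the series" means these few. Any claim that something is new, unique, unknown or untested is made for them only; others in the source may bear on it.

Compound 3 `CN1CCN(CCCOc2cccc3nc(Nc4ccc(F)c(F)c4)ccc23)CC1` gives 2630 nM in a functional assay on TK-10 cells (Homo sapiens) for inhibition, read by sulforhodamine B assay, with a stated time of 48 h (on this read-out lower numbers stand for stronger inhibition of growth and higher numbers for weaker inhibition of growth), the second highest of the three numbers in hand. Compound 1 `CN1CCN(CCCOc2cccc3nc(Nc4ccc(Cl)c(C(F)(F)F)c4)ccc23)CC1` gives 1800 nM and compound 2 `CC(C)c1ccc(Nc2ccc3c(OCCCN4CCN(C)CC4)cccc3n2)cc1` gives 16500 nM in this assay. The step of a 1.5-fold higher number from compound 1 to compound 3 (0.16 log units; within the scatter) stays within scatter, whereas a 9.2-fold higher number from compound 1 to compound 2 (0.96 log units; beyond the scatter) and a 6.3-fold lower number from compound 2 to compound 3 (0.80 log units; beyond the scatter) lie beyond it. Compound 4 `CN1CCN(CCCOc2cccc3nc(Nc4cc(Cl)cc(Cl)c4)ccc23)CC1` carries 3,5-dichlorophenyl in place of 3,4-difluorophenyl on a nitrogen on an aromatic ring. The step that bears most directly is a 1.5-fold higher number from compound 1 to compound 3 (0.16 log units; within the scatter), a swap between two halogenated phenyl groups at the same place; the step of a 6.3-fold lower number from compound 2 to compound 3 (0.80 log units; beyond the scatter) involves 4-isopropylphenyl and bears less. No step beyond the scatter is therefore expected in this assay, in either direction. Compound 4 is expected at 2200 nM, range 800 nM to 6000 nM, meaning a 1.2-fold lower number from compound 3 to compound 4 (0.08 log units; within the scatter).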

Compound 4, concentration for 50% growth inhibition: 1740 nM
Beside the measured number, compound 4's estimate is 1.3-fold (0.10 log units) above it; measured number inside the range.
By their numbers in this assay, from the lowest: compounds 4, 1 and 3 (each within the scatter of the next); then compound 2.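

In this assay a third halogenated phenyl group on this nitrogen falls in with the other two: a 1.5-fold lower number from compound 3 to compound 4 (0.18 log units; within the scatter) and a 1.0-fold lower number from compound 1 to compound 4 (0.01 log units; within the scatter) give no readable change from moving to 3,5-dichlorophenyl. With a 9.5-fold lower number from compound 2 to compound 4 (0.98 log units; beyond the scatter) as well, 4-isopropylphenyl stands apart from all three halogenated groups, though only compound 2 carries a non-halogenated group here. Nothing measured on hand explains these numbers. Open, on these data alone, is whether unsubstituted phenyl, or a methoxy or nitrile group on this ring, would sit with the halogenated groups or with 4-isopropylphenyl.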